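Chloro for trifluoromethyl between the ring nitrogens

The source may hold more compounds than are shown below. What is called first, only, known or untested is meant among the compounds shown, and "the series" means these compounds.

Three compounds of the series carry a measurement in an assay on Jurkat cells for activation of nuclear factor NF-kappa-B complex (Homo sapiens); a higher number here means a weaker inhibitor, a lower number a stronger inhibitor. Compound 1 `O=C(Nc1cc(C(F)(F)F)cc(C(F)(F)F)c1)c1cnc(Cl)nc1C(F)(F)C(F)(F)F` gives 800 nM. Within the data shown here, compound 2 `CCc1nc(Cl)ncc1C(=O)Nc1cc(C(F)(F)F)cc(C(F)(F)F)c1` gives 400 nM; the step of a 2.0-fold lower number from compound 1 to compound 2 (0.30 log units; within the scatter) is the only single-point change measured so far. Compound 3 `O=C(Nc1cc(C(F)(F)F)cc(C(F)(F)F)c1)c1cnc(C(F)(F)F)nc1C(F)(F)F` reaches only the assay limit of > 10000 nM, so its standing is a limit and not a number, the only one of the three at the limit of > 10000 nM in this assay, at which 1 of the 3 values shown sits.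

Compound 4 `O=C(Nc1cc(C(F)(F)F)cc(C(F)(F)F)c1)c1cnc(Cl)nc1C(F)(F)F` is the next candidate. It differs from compound 3 by chloro in place of trifluoromethyl on an aromatic carbon. Among the measured compounds shown here, no measured step covers this change: the step from compound 1 to compound 2 touches the other substituent on the shared core, while compounds 1 and 2 both carry chloro where compound 3 carries trifluoromethyl, and both give numbers well inside the measured range. The return to chloro is therefore expected to take compound 4 off the limit, in a downward step beyond the scatter, toward the numbers of compounds 1 and 2. Compound 4 is estimated at 700 nM, with a range from 250 nM to 3000 nM. The expected step is an at least 14-fold lower number from compound 3 to compound 4 (1.15 log units; beyond the scatter).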

Compound 4, half-maximal inhibitory concentration: 50 nM
Compound 4: middle estimate off by 14-fold (1.15 log units), on the high side; the measured number lies below the stated range.
By their numbers in this assay, from the lowest: compound 4; then compounds 2 and 1 (each within the scatter of the next). At a limit, above all of these: compound 3.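

In this assay, chloro in place of trifluoromethyl between two ring nitrogen atoms gives an at least 200-fold lower number from compound 3 to compound 4 (2.30 log units; beyond the scatter), so the group at this position separates a measurable number from no measurable number in this short set. Compound 3 stands at a limit and not at a number, so that step gives only a minimum size: the limit of > 10000 nM in this assay, at which 1 of the 4 values shown sits. With chloro held, the other substituent on the shared core also counts, which the earlier pair within the scatter did not show: trifluoromethyl gives an 8.0-fold lower number from compound 2 to compound 4 (0.90 log units; beyond the scatter) and a 16-fold lower number from compound 1 to compound 4 (1.20 log units; beyond the scatter).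

On these data alone, whether an amine, a methoxy group or a nitrile between two ring nitrogen atoms would keep the number of compound 4 stays open. So does the effect of methyl or a longer chain on the other substituent's carbon.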